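Compound 4 in a cytotoxicity series: from a limit onward

The source may report more compounds than this note shows. Statements on the series, on what has been measured and on what is new or still open speak of the compounds shown alone.

Measured so far:
compound 1 `Cn1ncc([N+](=O)[O-])c1C(=O)Nc1ccc2nc(NC(=O)C3CCCCC3)sc2c1`: 0.026 ug/mL
compound 2 `Cc1ccc(F)cc1S(=O)(=O)Nc1ccc2nc(NC(=O)C3CCCCC3)sc2c1`: 0.7 ug/mL
compound 3 `O=C(O)CCC(=O)Nc1nc2ccc(NC(=O)c3c(Cl)cccc3Cl)cc2s1`: > 6.6 ug/mL

Of the compounds shown here, three share a core and have been tested in a functional assay on WI-38 VA13 cells (Homo sapiens) for cytotoxicity; a lower number here means that less compound is needed, a higher number that more compound is needed for the effect. Compound 1 gives 0.026 ug/mL, and compound 2 gives 0.7 ug/mL. Compound 3 stands apart: its result is a limit of the assay, not a number, and it sits at the limit of > 6.6 ug/mL in this assay, at which 1 of the 3 values shown sits. Within the data shown here, no two of the measured compounds differ in only one place, so no single step between them can be read off.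

Compound 4 `COc1ccccc1Nc1nc2ccc(NC(=O)c3c(Cl)cccc3Cl)cc2s1` is the next compound, not yet measured. It differs from compound 3 in one place: 2-methoxyphenyl in place of (2-carboxyethyl)carbonyl on a nitrogen on an aromatic ring. The group that leaves carries a carboxylic acid; the group that enters is an aromatic ring bearing a methoxy group.

Compound 3 shows only a limit. The size of the step therefore cannot be anchored on a measured number. The step of an at least 4.4-fold lower number from compound 3 to compound 4 (0.64 log units; beyond the scatter) is nevertheless expected to move toward a lower number, beyond the usual scatter, bringing compound 4 closer to the region where compound 1 and compound 2 sit. Compound 4 is therefore expected to give about 1.5 ug/mL, somewhere between 0.2 ug/mL and 8 ug/mL.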

Compound 4, half-maximal effective concentration: > 7.2 ug/mL
Compound 4 ended at the assay's limit (the forecaster's own chance of this, stated with the estimate: 25%); middle value at least 4.8-fold (0.68 log units) from the limit.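

In this assay compound 4 gives > 7.2 ug/mL as a limit of the assay, not a number. Compound 3 likewise gives > 6.6 ug/mL as a limit. Among these compounds, no step between compound 3 and compound 4 can therefore be read. The compounds shown leave open whether 2-methoxyphenyl in place of (2-carboxyethyl)carbonyl shifts the read-out at all.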